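Methoxy addition on chromone cores with no measurable cytotoxicity

The source may hold more compounds than are shown below. What is called first, only, known or untested is meant among the compounds shown, and "the series" means these compounds.

Compound 1 `O=C(O)c1c(-c2ccc([N+](=O)[O-])cc2)oc2ccccc2c1=O` in a functional assay on SK-MEL cells (Homo sapiens) for cytotoxicity, read by MTT assay, with a stated time of 6 days (on this read-out higher numbers stand for an effect only at larger amounts of compound and lower numbers for an effect already at smaller amounts), gives > 25 ug/mL, which is a limit of the assay.
Compound 2 `COc1ccc2oc(-c3ccc([N+](=O)[O-])cc3)c(C(=O)O)c(=O)c2c1` gives > 25 ug/mL, again a limit.
Compound 3 `COc1ccc2c(=O)cc(-c3cc(OC)c(OC)c(OC)c3)oc2c1` gives > 25 ug/mL, also a limit.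

Compound 4 `COc1cc(-c2cc(=O)c3ccc(OC)c(OC)c3o2)cc(OC)c1OC` has not been measured. It arises from compound 3 by methoxy in place of hydrogen on an aromatic carbon. The same kind of change turns compound 1 into compound 2, by methoxy in place of hydrogen on an aromatic carbon; there the place is meta to a fused ring and para to a fused ring, whereas in compound 4 it is ortho to a fused ring, ortho to a methoxy group and meta to a fused ring. The step that the two limits leave unreadable from compound 1 to compound 2 cannot be sized, because of the limit of > 25 ug/mL in this assay, at which 3 of the 3 values shown sit. The difference between the two cores is not broken down here. For compound 4 a step that the limit leaves unreadable from compound 3 to compound 4 is expected to leave it at the limit as well, so compound 4 is estimated at 40 ug/mL.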

Compound 4, concentration for half-maximal effect: > 25 ug/mL
Compound 4 was reported as a limit; the forecaster's own chance of this, stated with the estimate: 80%; the middle value lies beyond the limit too.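

No step can be read from compound 3 to compound 4, since both sit at a limit: the limit of > 25 ug/mL in this assay, at which 4 of the 4 values shown sit. The compounds shown leave open whether methoxy in place of hydrogen shifts the effect in this assay at all.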